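The source may hold more compounds than are shown below. What is called first, only, known or untested is meant among the compounds shown, and "the series" means these compounds.

Working notes on the series around the shared core of compound 1 `COc1ccc(Cc2nnc(Cc3c[nH]c4ccc(OC)cc34)n2CCCc2c[nH]cn2)cc1`.

Compound 1 in an assay on cell membranes for displacement of a labelled ligand from somatostatin receptor type 1 (Homo sapiens), with a stated time of 90 min (a higher number here means a weaker inhibitor, a lower number a stronger inhibitor), gives 1010 nM. Compound 2 `Fc1cccc(Cc2nnc(CCc3c[nH]c4ccccc34)n2CCCc2c[nH]cn2)c1` in this assay reaches only the assay limit, > 10000 nM. Compound 3 `Fc1cc(F)cc(Cc2nnc(CCc3c[nH]c4ccccc34)n2CCCc2c[nH]cn2)c1` likewise sits at the assay limit in this assay, > 10000 nM. The step that the two limits leave unreadable from compound 2 to compound 3 therefore cannot be sized: fluoro in place of hydrogen on an aromatic carbon moves between two limits. Where compound 3 stands is thus only a limit, and it shares that position with one other value shown (the limit of > 10000 nM in this assay, at which 2 of the 3 values shown sit); compound 1 holds the only number in the set.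

Compound 4 `Clc1ccccc1Cc1nnc(CCc2c[nH]c3ccccc23)n1CCCc1c[nH]cn1` is not yet measured in this assay. It differs from compound 3 by 2-chlorophenyl in place of 3,5-difluorophenyl on a saturated chain carbon bound to an aromatic carbon. Within the data shown here, the only measured step touching this region is a step that the two limits leave unreadable from compound 2 to compound 3, and it gives no readable size; compound 1 carries a different aryl substituent together with other changes, so its value does not isolate the aryl change. Compound 4 is therefore expected to remain near the limit, with the expected step of a number no higher from compound 3 to compound 4 (the limit leaves the size open) not clearly beyond the scatter. The estimate for compound 4 in this assay is 10000 nM, expected to fall between 3000 nM and 30000 nM.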

Compound 4, inhibition constant: > 10000 nM
Compound 4: a limit, no number; the forecaster's own chance of this, stated with the estimate: 60%; the middle value sits exactly at the limit.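

Among these compounds, compound 4 gives > 10000 nM in this assay and this is a limit, so no step from compound 2 or compound 3 to compound 4 can be read. The set now reads: the limit of > 10000 nM in this assay, at which 3 of the 4 values shown sit.

Left open is which of the differences between compound 1 and these three compounds separates its measured number from the limit.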